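Urea series on a shared core: cytotoxicity read-out

The compounds below may be only part of what the source reports. "The series", "measured", "known", "first", "only" and "open" are said of these compounds alone.

Measured so far:
compound 1 `Cc1cc(NC(=O)Nc2cccc(C(N)=O)c2)c2ccccc2n1` gives > 25000 nM
compound 2 `Cc1cc(NC(=O)Nc2ccc(F)c(F)c2)c2ccccc2n1` gives > 25000 nM
compound 3 `Cc1cc(NC(=O)Nc2ccc(Cl)cc2)c2ccccc2n1` gives > 25000 nM

In an ADME assay on Raji cells (Homo sapiens) for cytotoxicity, with a stated time of 72 h (on this read-out higher numbers stand for an effect only at larger amounts of compound and lower numbers for an effect already at smaller amounts), compound 1 reports only a limit, not a number. Compound 2 likewise reaches only a limit. Compound 3 also stops at a limit. All three values sit at the limit of > 25000 nM in this assay, at which 3 of the 3 values shown sit, so compound 1 cannot be placed above or below the other two; none is separated from the rest.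

Compound 4 `Cc1cc(NC(=O)Nc2cccc(C(C)(C)C)c2)c2ccccc2n1` differs from compound 1 by tert-butyl in place of carbamoyl on an aromatic carbon. Going by the values given here, no measured step between any two compounds exists to lean on. Since every value shown is a limit, no step beyond the scatter is expected; the estimated change a step that the limit leaves unreadable from compound 1 to compound 4 is taken as none. Compound 4 is therefore expected to give about 30000 nM, within 15000 nM to 80000 nM, most likely again reported as a limit.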

Compound 4, half-maximal effective concentration: > 25000 nM
Compound 4: no number, only a limit (the forecaster's own chance of this, stated with the estimate: 80%); the middle value lies beyond the limit too.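

No step can be read between compound 1 and compound 4, because both values are limits, not numbers: the limit of > 25000 nM in this assay, at which 4 of the 4 values shown sit. The compounds shown leave open at what concentration, if any, any of them gives an effect in this assay.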